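This account rests on a few compounds, and the source may have more. Where it says the series, first, only, none or still open, it means among the compounds named here.

Working notes on the series.

Compound 1 `Cc1cc(C(=O)O)nn1-c1ccc(S(=O)(=O)NC(=S)NCc2ccccc2)cc1` is the reference point. In a functional assay on the whole organism (blood, strain albino) with Mus musculus as the target, with stated times of 6 days and 4 h, at a dose of 0.4 mmol/kg by the oral route (a lower number here means less inhibition, a higher number more inhibition at the dose given (going by the name of the read-out)), compound 1 gives < 2%, which is a limit of the assay and not a number. Where compound 1 stands is therefore fixed only as the limit of < 2% in this assay, at which 1 of the 2 values shown sits. For the measured compounds named here, compound 2 `Cc1cc(C)n(-c2ccc(S(=O)(=O)NC(=O)NC3CCCCC3)cc2)n1`, which shares the sulfonyl-linked phenylpyrazole core but carries a urea and a cyclohexyl group, gives in this assay a reading of 10%; no single-point step connects compound 2 with compound 1, so the two values are only set side by side.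

Compound 3 `Cc1cc(C(=O)O)nn1-c1ccc(S(=O)(=O)NC(=S)Nc2ccccc2)cc1` has not yet been measured. It differs from compound 1 by phenyl in place of benzyl on an amide-type nitrogen. Going by the values given here, no measured pair covers a change of this kind, so its size cannot be read from the data. The step from compound 1 to compound 3 is expected to be small, within the usual scatter, as a number at least 3 percentage points higher from compound 1 to compound 3 (that floor lies within the scatter). Compound 3 is accordingly estimated at 5%, in the range 0% to 15%.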

Compound 3, a percentage reported as inhibition, in the whole organism at one dose (the size of the read-out at that dose, not a potency): 0%
Compound 3: the middle estimate sits 5 percentage points above what was measured; low and high end bracket the measured number.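

The step from compound 1 to compound 3 cannot be read, because the value of compound 1 is a limit of the assay and not a number: the limit of < 2% in this assay, at which 1 of the 3 values shown sits.

Going by these compounds, whether phenyl in place of benzyl on an amide-type nitrogen changes the reading in this assay therefore stays open.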